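The source may hold more compounds than are shown below. What is called first, only, known or untested is meant among the compounds shown, and "the series" means these compounds.

Working notes on a short series built on one shared core. Compound 1 `Fc1ccc(-n2c(S)nnc2Sc2nnc(-c3ccccc3)n2-c2ccccc2)cc1`, compound 2 `COc1ccc(-n2c(S)nnc2Sc2nnc(-c3ccccc3)n2-c2ccccc2)cc1` and compound 3 `Sc1nnc(CSc2nnc(-c3ccccc3)n2-c2ccccc2)n1-c1ccccc1` have been run in a functional assay on MDA-MB-231 cells (Homo sapiens) for inhibition, read by MTT assay, with a stated time of 48 h (on this read-out lower numbers stand for stronger inhibition and higher numbers for weaker inhibition), and compound 4 `Fc1ccc(-n2c(S)nnc2CSc2nnc(-c3ccccc3)n2-c2ccccc2)cc1` is the next member awaiting a number. In this assay compound 1 gives 29700 nM. In this assay compound 2 gives "not determined" (no result reported), so no number is in hand for it. In this assay, for the measured compounds named here, compound 3 gives 8570 nM, the lowest of the two numbers in hand; compound 1 stands well above it, beyond the scatter, but the two compounds differ in more than one place, so their values show only that the pair sits apart.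

Compound 4 departs from compound 3 by a single change: fluoro in place of hydrogen on an aromatic carbon. Going by the values given here, no measured pair differs in this way alone, so there is no step to lean on. The expectation is that the step of a 1.2-fold higher number from compound 3 to compound 4 (0.07 log units; within the scatter) in this assay will be small, in no set direction, and not beyond the scatter. Compound 4 is therefore estimated at 10000 nM in this assay. The range expected for compound 4 runs from 4000 nM to 25000 nM.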

Compound 4, half-maximal inhibitory concentration: 26800 nM
Compound 4: middle estimate off by 2.7-fold (0.43 log units), on the low side; the measured number lies above the stated range.
By their numbers in this assay, from the lowest: compound 3; then compounds 4 and 1 (each within the scatter of the next).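

For the compounds shown here, the change from phenyl to 4-fluorophenyl gives the first single-place reading: in this assay the step is a 3.1-fold higher number from compound 3 to compound 4 (0.50 log units; beyond the scatter) and so lies beyond the scatter. Inhibition on this read-out therefore weakens modestly when fluoro replaces hydrogen on this aromatic carbon, showing that the position is not indifferent to this change, at least in this one pair. No measurement in hand accounts for the step.

On these data alone, whether the step is particular to fluoro or would recur with chloro, hydroxyl or an amine at the same place remains open. Also open, as far as these compounds go, is whether the same change on the other phenyl rings of the shared core would read the same way.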